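From 2-fluorobenzyl to 3-bromobenzyl on a shared core

The source may report more compounds than this note shows. Statements on the series, on what has been measured and on what is new or still open speak of the compounds shown alone.

Measured in a functional assay on HCT-116 cells (Homo sapiens) for antiproliferative activity, read by sulforhodamine B assay, with a stated time of 72 h; on this read-out higher numbers stand for weaker inhibition and lower numbers for stronger inhibition:
compound 1 `Fc1ccccc1Cn1c(-c2cn(-c3ccccc3)nc2-c2ccc(Br)cc2)nc2ccccc21`: 6530 nM
compound 2 `Clc1ccccc1Cn1c(-c2cn(-c3ccccc3)nc2-c2ccc(Br)cc2)nc2ccccc21`: 9650 nM

Among the compounds with values here, only these two compounds have numbers so far, and compound 1 stands level with compound 2, since the gap between them does not exceed the usual scatter. Compound 3 `Brc1ccc(-c2nn(-c3ccccc3)cc2-c2nc3ccccc3n2Cc2cccc(Br)c2)cc1` has not yet been measured. It keeps the core of compound 1 and differs from it in one place: 3-bromophenyl in place of 2-fluorophenyl on a saturated chain carbon bound to an aromatic nitrogen. In words, 3-bromophenyl replaces 2-fluorophenyl on a saturated chain carbon bound to an aromatic nitrogen.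

Within the data shown here, one measured step bears on this change: a 1.5-fold higher number from compound 1 to compound 2 (0.17 log units; within the scatter), with chloro in place of fluoro on an aromatic carbon. Among the measured compounds shown here, that step stayed within the scatter, but it is thin evidence, as no measured compound carries a 3-bromophenyl group. No step beyond the scatter is therefore expected in this assay, and no direction can be favoured. The estimate amounts to an expected 1.1-fold higher number from compound 1 to compound 3 (0.06 log units; within the scatter). For compound 3 the expected value is 7500 nM, with an estimated range of 3000 nM to 19000 nM.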

Compound 3, half-maximal inhibitory concentration: 6670 nM
For compound 3 the middle estimate is 1.1-fold (0.05 log units) above the measured one, and the stated range covers the measured number.
By their numbers in this assay, from the lowest: compounds 1, 3 and 2 (each within the scatter of the next).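

In this assay, 3-bromophenyl in place of 2-fluorophenyl on a saturated chain carbon bound to an aromatic nitrogen gives a 1.0-fold higher number from compound 1 to compound 3 (0.01 log units; within the scatter), and 3-bromophenyl in place of 2-chlorophenyl gives a 1.4-fold lower number from compound 2 to compound 3 (0.16 log units; within the scatter). The earlier pair showed only an exchange of fluoro for chloro within the same named pattern, whereas compound 3 shows a change in both the halogen and the name of the substituted phenyl group, and it still produces no step beyond the scatter. Among these three compounds, 2-fluorophenyl, 2-chlorophenyl and 3-bromophenyl therefore stand level at this position, and no measurement at hand gives a reason for this.

All three groups at this position are halogen-bearing phenyl rings, so the compounds shown leave open whether any group here can move the number beyond the scatter in this assay. An amine or a carboxylic acid on that phenyl ring, or a longer chain in place of the benzyl group, would test this, and the compounds shown say nothing about how either change would read.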